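Turning one double bond from E to Z

A few compounds are considered here, and "the series" means these few. Any claim that something is new, unique, unknown or untested is made for them only; others in the source may bear on it.

compound 1 `CC#Cc1ccc(-c2ccc(C(O)CO)s2)s1` gives 48700 nM
compound 2 `C/C=C/C#CC#Cc1ccc(C(O)CO)s1` gives 28200 nM

Both values come from a functional assay on RAW264.7 cells (Mus musculus), read by colorimetric assay, with a stated time of 24 h, in the presence of a further agent that is not named here (on this read-out lower numbers stand for stronger inhibition and higher numbers for weaker inhibition), and lie within the usual scatter of each other, so on these numbers compound 2 cannot be told apart from compound 1. Compound 3 `C/C=C\C#CC#Cc1ccc(C(O)CO)s1` has not been measured yet. It differs from compound 2 as follows: the two compounds have the same atoms and bonds; at least one stereo element is drawn with a configuration in one of them and without one in the other: 1 of 2 stereo elements differ; a double bond is drawn E in compound 2 and Z in compound 3. The atoms and bonds stay the same, and a double bond drawn E in compound 2 is drawn Z in compound 3. For the measured compounds named here, no measured pair shows what such a change does in this assay, so the estimated step of a 1.0-fold lower number from compound 2 to compound 3 (0.00 log units; within the scatter) is expected to stay within the scatter, in neither direction. For compound 3 the estimated value is 28000 nM (expected range 14000 nM to 56000 nM).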

Compound 3, half-maximal inhibitory concentration: 12800 nM
The estimate for compound 3 lay 2.2-fold (0.34 log units) above the measured number; measured number below the stated range.
By their numbers in this assay, from the lowest: compound 3; then compounds 2 and 1 (each within the scatter of the next).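

In this assay, turning the double bond from E to Z brings a 2.2-fold lower number from compound 2 to compound 3 (0.34 log units; beyond the scatter), a modest step but the first one here that rises above the scatter, with no atom added or removed. For the compounds shown here, the earlier compounds offered no pair differing in one place, so this is the first sign that the geometry of this double bond alone can change the number. The only difference on record is this: the fact that one of compounds 2 and 3 is drawn with a defined configuration and the other without, at the place where they differ

Still open, as far as these compounds go, is whether the Z compound would keep its lower number if a longer chain or an amine were introduced. Why the Z form gives the lower number also remains unknown.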